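A few compounds are considered here, and "the series" means these few. Any claim that something is new, unique, unknown or untested is made for them only; others in the source may bear on it.

Compound 1 `COCC(C(=O)N1CCN(c2cccc(C(F)(F)F)c2)CC1)N1C(=O)CCC1=O`: 50%
Compound 2 `CC(C(=O)N1CCN(c2cccc(Cl)c2)CC1)N1C(=O)CCC1=O`: 100%
Compound 3 `CC(C(=O)N1CCN(c2cccc(F)c2)CC1)N1C(=O)CCC1=O`: 50%

All three numbers come from a functional assay on the whole organism (strain Swiss) with Mus musculus as the target, in the maximal electroshock model, with a stated time of 0.5 h, at a dose of 300 mg/kg by the intraperitoneal route; a lower number here means a weaker effect, a higher number a stronger effect of the compound at the dose given. Compound 1 stands level with compound 3 at the digits given, the two together being the lowest of the three numbers; compound 2 stands above compound 1 by a margin beyond the scatter. Going by the values given here, the single measured step in this assay, a number 50 percentage points lower from compound 2 to compound 3 (beyond the scatter), concerns fluoro in place of chloro on an aromatic carbon and leaves the chain carrying the succinimide-type ring and the carbonyl untouched.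

Compound 4 `CCC(C(=O)N1CCN(c2cccc(C(F)(F)F)c2)CC1)N1C(=O)CCC1=O` has not yet been measured. It differs from compound 1 by methyl in place of methoxy on a saturated chain carbon, two bonds along the chain from an amide-type nitrogen in a ring and a carbonyl carbon. Among the compounds with values here, no measured step touches this chain position; the step from compound 2 to compound 3 concerns the aromatic carbon only and cannot be carried over to a change on the chain. The only anchor is therefore the value of compound 1 itself. The expected step for compound 4 in this assay is no change at the digits printed from compound 1 to compound 4 (within the scatter), with no shift beyond the scatter expected in either direction. Compound 4 is estimated at 50%, with a range from 25% to 80%. Within the data shown here, the range is wide; no directly comparable step is available to narrow it.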

Compound 4, a percentage reported as activity, at one dose (the size of the read-out at that dose, not a potency): 50%
The estimate for compound 4 equals the measured number at the digits printed; the range from low to high includes it.
By their numbers in this assay, from the lowest: compounds 1, 3 and 4 (each within the scatter of the next); then compound 2.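

In this assay this chain position now has its first measured step: methyl in place of methoxy on a saturated chain carbon, two bonds along the chain from an amide-type nitrogen in a ring and a carbonyl carbon (no change at the digits printed from compound 1 to compound 4 (within the scatter)). With the trifluoromethyl-bearing remainder of compound 1 held constant, the loss of the methoxy oxygen, and with it the one hydrogen-bond acceptor counted for that group, leaves the read-out at this dose within the scatter, whereas the earlier step on the aromatic carbon was beyond it (a number 50 percentage points lower from compound 2 to compound 3 (beyond the scatter)). No measurement on hand offers an explanation for this result.

The compounds shown leave open how an amine, a carboxylic acid or a longer chain such as propyl would read on this same saturated chain carbon, since methoxy and methyl are the only two groups compared there. They also leave open whether the methoxy-to-methyl step would read the same with chloro on the aromatic carbon, the group of compound 2 (100%), and whether readings at other doses would separate compound 1 from compound 4.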